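This account rests on a few compounds, and the source may have more. Where it says the series, first, only, none or still open, it means among the compounds named here.

Of the compounds shown here, three have so far been measured in a physicochemical assay for lipophilicity, measured as octanol-water partition; on this read-out lower numbers stand for lower lipophilicity and higher numbers for higher lipophilicity. Compound 1, `CCCOc1c(Cl)cc(N/C=N/OCC)cc1Cl`, gives 4.6 in this assay. Compound 2, `CCO/N=C/Nc1cc(Cl)c(OC(C)C)c(Cl)c1`, carries isopropyl in place of propyl on an oxygen on an aromatic ring relative to compound 1; in this assay compound 2 gives 4.4. The resulting step of a number 0.20 log units lower from compound 1 to compound 2 (within the scatter) is small. Compound 3, `C#CCc1c(Cl)cc(N/C=N/OCCC)cc1Cl`, rests on a different core from compound 1, and the difference between the two cores is not broken down here. In this assay compound 3 gives 4, the lowest of the three numbers, with compound 2 nearest and compound 1 furthest, both beyond the scatter.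

Compound 4, `C#CCc1c(Cl)cc(N/C=N/OC(C)C)cc1Cl`, has not yet been measured. It differs from compound 3 by isopropyl in place of propyl on an oxygen. This is the same kind of change as the one from compound 1 to compound 2, and it occurs twice in all among these compounds, but the place is not identical: from compound 1 to compound 2 the oxygen sits on an aromatic ring and its other neighbours are aromatic carbon, whereas from compound 3 to compound 4 the oxygen's other neighbours are double-bonded nitrogen. For compound 4 in this assay a step of similar size is expected, a number 0.20 log units lower from compound 3 to compound 4 (within the scatter), because the measured step of a number 0.20 log units lower from compound 1 to compound 2 (within the scatter) lay within the scatter. Compound 4 is therefore estimated at 3.8, with a likely range from 3.4 to 4.2.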

Compound 4, partition coefficient: 3.9
The estimate for compound 4 lay 0.10 log units below the measured number; the range from low to high includes it.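

In this assay the exchange of propyl for isopropyl gives a number 0.10 log units lower from compound 3 to compound 4 (within the scatter), and on the core of compound 1 the same kind of exchange gave a number 0.20 log units lower from compound 1 to compound 2 (within the scatter), so in both of the pairs shown the exchange stays within the scatter. Going by these compounds alone, this shows that a small step seen on one core was also seen on the other, but it rests on only two pairs, and the place differs as well as the core: an oxygen on an aromatic ring in the first pair, and an oxygen whose other neighbours are double-bonded nitrogen in the second, so core and place cannot be told apart and no rule for further cores follows. Nothing at hand accounts for the size of either step.

The compounds shown leave open whether a longer chain such as butyl, or a group of another kind such as an amine or a carboxylic acid, on either oxygen would give a step beyond the scatter. They also leave open whether the exchange of propyl for isopropyl would stay as small on a core other than these two.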